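Iodomethyl in place of hydroxymethyl on the acid

The source may hold more compounds than are shown below. What is called first, only, known or untested is meant among the compounds shown, and "the series" means these compounds.

Values in a functional assay on HCT-116 cells (Homo sapiens) for inhibition, with a stated time of 72 h (a lower number here means a stronger inhibitor, a higher number a weaker inhibitor), so far:
- Compound 1 `CNC(=O)C1=C[C@@H]2[C@@H](C(C)C)CC[C@@]3(CO3)[C@H]2C(=O)OC1` at 7100 nM as a number
- Compound 2 `CNC(=O)C1=C[C@@H]2[C@@H](C(C)C)CC[C@@](O)(CO)[C@H]2C(=O)OC1` at > 32000 nM as a limit
- Compound 3 `CC(C)[C@H]1CC[C@@](O)(CO)[C@H]2C(=O)OCC(C(=O)O)=C[C@H]12` at > 32000 nM as a limit

Compound 3 has only a limit and no number (the limit of > 32000 nM in this assay, at which 2 of the 3 values shown sit). Compound 4 `CC(C)[C@H]1CC[C@@](O)(CI)[C@H]2C(=O)OCC(C(=O)O)=C[C@H]12` carries iodo in place of hydroxy on a saturated chain carbon bound to a saturated ring carbon. Among the measured compounds shown here, no measured step covers this place. For the measured compounds named here, the one step available, a step that the two limits leave unreadable from compound 2 to compound 3, lies on a carbonyl carbon. Going by the values given here, compound 1 at 7100 nM holds the only number, and this modest level guides the expectation. The expected step is an at least 2.0-fold lower number from compound 3 to compound 4 (0.30 log units; that floor lies within the scatter) towards stronger inhibition in this assay, and another reading at the limit remains possible. For compound 4 the estimate is 16000 nM, with an expected range of 5000 nM to 32000 nM.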

Compound 4, half-maximal inhibitory concentration: 2140 nM
Compound 4: the middle estimate sits 7.5-fold (0.87 log units) above what was measured; the whole stated range lies above it.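

In this assay, the saturated chain carbon bound to a saturated ring carbon responds strongly to what it carries: iodo in place of hydroxy gives an at least 14-fold lower number from compound 3 to compound 4 (1.17 log units; beyond the scatter) on the acid. Among the compounds shown here, this is the first readable step, and it shows that the carboxylic acid does not by itself exclude a measured number. The size is only a floor, because compound 3 has a limit and no number: the limit of > 32000 nM in this assay, at which 2 of the 4 values shown sit.

Going by these compounds, whether chloromethyl or bromomethyl at this place gives a similar step remains open. Also open, on these data alone, is what iodomethyl does on the methylamide of compound 2, whose step to the acid cannot be read.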